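The source may hold more compounds than are shown below. What is called first, only, known or untested is meant among the compounds shown, and "the series" means these compounds.

Working notes on the series. The shared core is that of compound 1 `COc1cc(Nc2ncnc3c(NC(=O)Nc4cccc(Oc5ccccc5)c4)cccc23)cc(OC)c1`, which in a functional assay on RT-112 cells (Homo sapiens) for antiproliferative activity, read by MTT assay, with a stated time of 72 h (on this read-out higher numbers stand for weaker inhibition of growth and lower numbers for stronger inhibition of growth), gives 14000 nM. Compound 2 `COc1cc(Nc2ncnc3c(NC(=O)Nc4ccc([N+](=O)[O-])cc4)cccc23)cc(OC)c1` carries a 4-nitrophenyl on the amide-type nitrogen. In this assay compound 2 returns only a limit of the assay, > 20000 nM. Compound 3 `COc1cc(Nc2ncnc3c(NC(=O)Nc4ccc(C(F)(F)F)cc4[N+](=O)[O-])cccc23)cc(OC)c1` also returns only a limit, > 20000 nM. Compound 2 thus stands at the weak end of what is shown, without a number of its own, a position described by the limit of > 20000 nM in this assay, at which 2 of the 3 values shown sit, and shared with compound 3. Going by the values given here, compound 1 is the sole member with a measured value for growth inhibition, and even that sits high on the scale.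

Compound 4 `COc1cc(Nc2ncnc3c(NC(=O)Nc4cccc(C(F)(F)F)c4F)cccc23)cc(OC)c1` differs from compound 2 in one place: 2-fluoro-3-(trifluoromethyl)phenyl in place of 4-nitrophenyl on an amide-type nitrogen. Compound 3 also carries a trifluoromethyl on its phenyl and stays at the limit, while compound 1 with its phenoxy gives a number. Among the compounds with values here, no measured step connects these changes, so the step from compound 2 to compound 4 can only be expected. The expected step is an at least 1.2-fold lower number from compound 2 to compound 4 (0.09 log units; that floor lies within the scatter), none beyond the scatter and in no firm direction. Compound 4 is therefore estimated at 16000 nM, with a range from 5000 nM to 40000 nM.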

Compound 4, concentration for 50% growth inhibition: 471 nM
For compound 4 the middle estimate is 34-fold (1.53 log units) above the measured one, and the stated range ends above it.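

Going by these compounds alone, the position on the amide-type nitrogen, whose other neighbour is the carbonyl carbon, proves able to carry strong growth inhibition in this assay, which the earlier compounds did not show: 2-fluoro-3-(trifluoromethyl)phenyl in place of 4-nitrophenyl gives an at least 42-fold lower number from compound 2 to compound 4 (1.62 log units; beyond the scatter). This step is a floor and not a measured size because compound 2 has no number of its own, only a limit of the assay: the limit of > 20000 nM in this assay, at which 2 of the 4 values shown sit. Compound 3, which also carries a trifluoromethyl on its phenyl, returns only a limit of the assay, > 20000 nM, so a trifluoromethyl on the phenyl does not alone decide the outcome at this position.

The compounds shown do not separate the fluorine of the entering group from its trifluoromethyl, so what each contributes, and whether their placing on the phenyl matters, stays open. Also open, going by these compounds, is how this position would read in this assay with an amine or a carboxylic acid on the phenyl, or with a longer chain in place of the phenyl.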